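A few compounds are considered here, and "the series" means these few. Any claim that something is new, unique, unknown or untested is made for them only; others in the source may bear on it.

Measured so far in a functional assay on SW 1116 cells (Homo sapiens) for antiproliferative activity, read by MTT assay, with a stated time of 24 h; a higher number here means a weaker inhibitor, a lower number a stronger inhibitor:
- compound 1 `c1ccc(CSc2nnc(-c3ccc4c(c3)OCCO4)n2-c2ccccc2)cc1` gives 7930 nM
- compound 2 `Fc1cccc(F)c1CSc1nnc(-c2ccc3c(c2)OCCO3)n1-c1ccccc1` gives 9010 nM

Among the compounds with values here, compound 2 stands at 9010 nM, within the scatter of the only other measured value, so the pair gives no order. Compound 3 `Brc1ccc(CSc2nnc(-c3ccc4c(c3)OCCO4)n2-c2ccccc2)cc1` is not yet measured. It differs from compound 2 as follows: 4-bromophenyl in place of 2,6-difluorophenyl on a saturated chain carbon bound to a sulfur, with 4-bromophenyl in place of 2,6-difluorophenyl on a saturated chain carbon bound to a sulfur.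

Within the data shown here, one measured step bears on this, at the same place: 2,6-difluorophenyl in place of phenyl, a 1.1-fold higher number from compound 1 to compound 2 (0.06 log units; within the scatter). Among the measured compounds shown here, no measured compound carries a 4-bromophenyl group, so this single step is a thin guide and the range is kept wide. No change beyond the scatter is therefore expected in this assay. The expected step is a 1.3-fold lower number from compound 2 to compound 3 (0.11 log units; within the scatter). For compound 3 the estimated value is 7000 nM, with an expected range of 2500 nM to 17000 nM.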

Compound 3, half-maximal inhibitory concentration: 5810 nM
Estimate against measurement, compound 3: 1.2-fold (0.08 log units) above; the measured number falls inside the stated range.
By their numbers in this assay, from the lowest: compounds 3, 1 and 2 (each within the scatter of the next).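

In this assay the 4-bromophenyl group on a saturated chain carbon bound to a sulfur gives a third aryl group at this place, and the two new steps, a 1.6-fold lower number from compound 2 to compound 3 (0.19 log units; within the scatter) and a 1.4-fold lower number from compound 1 to compound 3 (0.14 log units; within the scatter), both stay within the scatter. Bromo in place of hydrogen on an aromatic carbon and the exchange of 2,6-difluorophenyl for 4-bromophenyl therefore give no readable change, and compounds 1, 2 and 3 remain without an order. Nothing on hand accounts for this flat result.

Open, going by these compounds, is whether this place responds to anything other than a plain or halogen-bearing phenyl, such as a carboxylic acid or an amine on the ring. A longer chain between the sulfur and the ring also remains untested in the compounds shown, as does any change to the shared core.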